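A few compounds are considered here, and "the series" means these few. Any claim that something is new, unique, unknown or untested is made for them only; others in the source may bear on it.

In a functional assay on U2OS cells for antagonist activity at proto-oncogene Wnt-3 (Homo sapiens), read by a luciferase reporter, with a stated time of 18 h (a lower number here means that less compound is needed, a higher number that more compound is needed for the effect), three close relatives of compound 4 have already been measured. Compound 1 `CC(C)(C)C(=O)N1CCC[C@H]1C(=O)N1CCC(NS(=O)(=O)c2cc(S(=O)(=O)c3ccccc3)ccc2C(F)(F)F)CC1` gives 270 nM, compound 2 `CN(C)CC(=O)N1CCC[C@H]1C(=O)N1CCC(NS(=O)(=O)c2cc(S(=O)(=O)c3ccccc3)ccc2C(F)(F)F)CC1` gives 310 nM, and compound 3 `CCNC(=O)N1CCC[C@H]1C(=O)N1CCC(NS(=O)(=O)c2cc(S(=O)(=O)c3ccccc3)ccc2C(F)(F)F)CC1` gives 90 nM. Compound 3 stands lowest of the three, since a 3.0-fold lower number from compound 1 to compound 3 (0.48 log units; beyond the scatter) and a 3.4-fold lower number from compound 2 to compound 3 (0.54 log units; beyond the scatter) both lie beyond the scatter, while a 1.1-fold higher number from compound 1 to compound 2 (0.06 log units; within the scatter) lies within it. Compound 4 `O=C([C@@H]1CCCN1C(=O)Nc1ccccc1)N1CCC(NS(=O)(=O)c2cc(S(=O)(=O)c3ccccc3)ccc2C(F)(F)F)CC1` differs from compound 3 by phenyl in place of ethyl on an amide-type nitrogen. Every measured step exchanges the group attached to the carbonyl carbon; none of them touches the amide-type nitrogen that is altered here, so the three steps only show that compound 3's ethylamino arrangement is the best of those tried and give no direct guide to replacing ethyl with phenyl. The step expected in this assay is therefore small, a 1.2-fold higher number from compound 3 to compound 4 (0.09 log units; within the scatter), not beyond the scatter. Compound 4 is estimated at 110 nM, with a range from 40 nM to 320 nM.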

Compound 4, half-maximal effective concentration: 310 nM
The estimate for compound 4 lay 2.8-fold (0.45 log units) below the measured number; measured number inside the range.
By their numbers in this assay, from the lowest: compound 3; then compounds 1, 2 and 4 (each within the scatter of the next).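

In this assay, the amide-type nitrogen is sensitive to what it carries, with phenyl in place of ethyl giving a 3.4-fold higher number from compound 3 to compound 4 (0.54 log units; beyond the scatter) in this assay. The low number of compound 3 therefore does not follow from having a nitrogen on the carbonyl carbon alone, since the anilino group also places one there and still gives no change at the digits printed from compound 2 to compound 4 (within the scatter) and a 1.1-fold higher number from compound 1 to compound 4 (0.06 log units; within the scatter), which leaves compound 4 not separable from the two compounds that lack this nitrogen. Nothing available gives a reason for the step from ethyl to phenyl.

Only ethyl and phenyl are shown on this nitrogen, so it remains open whether methyl, cyclohexyl or benzyl would give a number closer to compound 3 or to compound 4. As far as these compounds go, it is also open whether a methoxy group or a fluorine on the phenyl ring would move the number of compound 4.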